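The source may hold more compounds than are shown below. What is called first, only, known or untested is meant among the compounds shown, and "the series" means these compounds.

In an assay on CHO cells for displacement of a labelled ligand from transient receptor potential cation channel subfamily V member 1 (Homo sapiens), read by scintillation counting, with a stated time of 60 min (a lower number here means a stronger inhibitor, a higher number a weaker inhibitor), compound 3 `CN(C)C1(Cc2ccccc2)CCN(c2cc(C(F)(F)F)ccc2CNC(=O)Nc2ccc3cnccc3c2)CC1` gives 62 nM, which places it second highest of the three numbers measured: compound 1 `CN(C)C1(Cc2ccccc2)CCN(c2cc(C(F)(F)F)ccc2CNC(=O)Nc2ccc(NS(C)(=O)=O)c(F)c2)CC1` gives 1160 nM in this assay, and compound 2 `CN(C)C1(Cc2ccccc2)CCN(c2cc(C(F)(F)F)ccc2CNC(=O)Nc2cccc3c2CC(O)CC3)CC1` gives 0.95 nM. The steps from compound 1 to compound 3 and from compound 2 to compound 3 were both large, a 19-fold lower number from compound 1 to compound 3 (1.27 log units; beyond the scatter) and a 65-fold higher number from compound 2 to compound 3 (1.81 log units; beyond the scatter), and the step from compound 1 to compound 2 was larger still, a 1200-fold lower number from compound 1 to compound 2 (3.09 log units; beyond the scatter). All three steps show that the group on the amide-type nitrogen of the shared core moves the number over a very wide span.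

Compound 4 `CN(C)C1(Cc2ccccc2)CCN(c2cc(C(F)(F)F)ccc2CNC(=O)Nc2cccc3ncccc23)CC1` carries the change (quinolin-5-yl in place of isoquinolin-6-yl on an amide-type nitrogen). Within the data shown here, no measured step covers this particular exchange, and the two groups have the same atoms joined differently, so the earlier steps only tell that this position is sensitive, not in which direction a rearrangement of the ring nitrogen would move the number. The step from compound 3 to compound 4 is therefore expected to be modest, a 2.1-fold lower number from compound 3 to compound 4 (0.32 log units; beyond the scatter), with a broad range around it. In this assay compound 4 is estimated at 30 nM, between 4 nM and 250 nM.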

Compound 4, inhibition constant: 10.8 nM
The estimate for compound 4 lay 2.8-fold (0.44 log units) above the measured number; the measured number falls inside the stated range.
By their numbers in this assay, from the lowest: compound 2; then compound 4; then compound 3; then compound 1.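

Even with the atom count, the hydrogen-bond donor and acceptor counts and the place on the amide-type nitrogen all unchanged, exchanging isoquinolin-6-yl for quinolin-5-yl still shifts the result in this assay (a 5.7-fold lower number from compound 3 to compound 4 (0.76 log units; beyond the scatter)), so the way these atoms are joined matters at this position, not only which atoms are present. The quinolin-5-yl group also gives an intermediate result among the groups at this position: it is far ahead of the 3-fluoro-4-(methanesulfonamido)phenyl group (a 110-fold lower number from compound 1 to compound 4 (2.03 log units; beyond the scatter)) but falls short of the 3-hydroxy-1,2,3,4-tetrahydronaphthalen-5-yl group (an 11-fold higher number from compound 2 to compound 4 (1.06 log units; beyond the scatter)). Nothing at hand explains why moving the ring nitrogen has this effect.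

The compounds shown leave open whether the isoquinolin-5-yl group would behave like quinolin-5-yl or like isoquinolin-6-yl, which would help separate the attachment point from the place of the ring nitrogen. They also leave open what the hydroxyl group contributes in compound 2, and whether a hydroxyl or an amine on the quinolin-5-yl group would narrow the remaining gap.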